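The compounds below may be only part of what the source reports. "The series", "measured", "known", "first", "only" and "open" are said of these compounds alone.

In a functional assay on HL-60 cells (Homo sapiens) for cytotoxicity, read by MTT assay, with a stated time of 48 h (a higher number here means a weaker inhibitor, a lower number a stronger inhibitor), compound 1 (`COc1cc(NC(=O)n2cc(-c3ccc(O)cc3)n(-c3cc(OC)c(OC)c(OC)c3)c2=O)cc(OC)c1OC`) gives 6300 nM and compound 2 (`COc1ccc(-c2cn(C(=O)Nc3cc(OC)c(OC)c(OC)c3)c(=O)n2-c2cc(OC)c(OC)c(OC)c2)cc1N`) gives 3100 nM. Compound 3 (`COc1cc(-n2c(-c3ccccc3)cn(C(C)=O)c2=O)cc(OC)c1OC`) reads 5600 nM and so lies inside that span, within the scatter of compound 1 and of compound 2 alike. Compound 4 (`COc1ccc(-c2cn(C(C)=O)c(=O)n2-c2cc(OC)c(OC)c(OC)c2)cc1`) has not yet been measured. It differs from compound 3 by a single change methoxy in place of hydrogen on an aromatic carbon, para to a large group, which turns phenyl into 4-methoxyphenyl.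

Going by the values given here, no measured pair carries this exact change. Among the compounds with values here, the only measured step that touches the same ring is 3-amino-4-methoxyphenyl in place of 4-hydroxyphenyl, which gave a 2.0-fold lower number from compound 1 to compound 2 (0.31 log units; beyond the scatter). That step is modest, involves different groups and comes from compounds that also differ from compound 3 elsewhere, so it offers only indirect guidance. A similarly modest move toward a lower number in this assay is therefore expected, though a result within the scatter would be no surprise. The expected change is a 1.9-fold lower number from compound 3 to compound 4 (0.27 log units; within the scatter) in size. For compound 4 the estimated value is 3000 nM, with an expected range of 1000 nM to 7000 nM.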

Compound 4, half-maximal inhibitory concentration: 5500 nM
Compound 4: middle estimate off by 1.8-fold (0.26 log units), on the low side, within the range that was stated.
By their numbers in this assay, from the lowest: compounds 2, 4, 3 and 1 (each within the scatter of the next, the first and the last beyond it).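

In this assay, methoxy in place of hydrogen on an aromatic carbon, para to a large group, gives a 1.0-fold lower number from compound 3 to compound 4 (0.01 log units; within the scatter), so in this pair phenyl and 4-methoxyphenyl cannot be told apart. Going by these compounds alone, this is the first direct reading of that change at this position; the only earlier step on the same ring, a 2.0-fold lower number from compound 1 to compound 2 (0.31 log units; beyond the scatter), replaced 4-hydroxyphenyl with 3-amino-4-methoxyphenyl on a different background, and its modest shift does not carry over to this pair. No supporting evidence is available to explain why the added methoxy leaves the number in the same place.

As far as these compounds go, whether a different group at this position, such as a fluorine atom, a carboxylic acid or a longer chain like ethoxy, would move the number beyond the scatter remains open. Also open is whether methoxy in place of hydrogen would read the same on the background shared by compound 1 and compound 2, since the compounds shown offer no such pair.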